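A few compounds are considered here, and "the series" means these few. Any claim that something is new, unique, unknown or untested is made for them only; others in the source may bear on it.

Compound 1 `O=C(/C=C\Nc1cnc2ccccc2c1)c1nc(-c2ccccc2)n2ccccc12` gives 19700 nM in a functional assay on BT-474 cells (Homo sapiens) for cytotoxicity, read by MTT assay, with a stated time of 48 h; a lower number here means a stronger inhibitor, a higher number a weaker inhibitor.
Compound 2 `O=C(/C=C\Nc1ccc(Cl)cc1)c1nc(-c2ccc(C(F)(F)F)cc2)n2ccccc12` gives 3820 nM in this assay.

Of the two measured compounds, compound 2 holds the lower number, and its gap to compound 1 lies beyond the usual scatter. Compound 3 `O=C(/C=C\Nc1cnc2ccccc2c1)c1nc(-c2ccc(C(F)(F)F)cc2)n2ccccc12` has not yet been measured. It differs from compound 2 by quinolin-3-yl in place of 4-chlorophenyl on an amine nitrogen. Going by the values given here, no measured pair isolates this change, so its effect must be guessed; the higher number seen for compound 1 hints that the quinolin-3-yl variant may be weaker. Compound 3 is therefore expected to lose some potency, with a step of a 2.1-fold higher number from compound 2 to compound 3 (0.32 log units; beyond the scatter), giving an estimated 8000 nM, in the range 2500 nM to 25000 nM.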

Compound 3, half-maximal inhibitory concentration: > 30000 nM
Compound 3: only a limit was reported; the forecaster's own chance of this, stated with the estimate: 5%; at least 3.7-fold (0.57 log units) between middle value and limit.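

Quinolin-3-yl in place of 4-chlorophenyl on the amine nitrogen weakens the compound in this assay, with an at least 7.8-fold higher number from compound 2 to compound 3 (0.89 log units; beyond the scatter); no earlier pair isolated this change. The reading for compound 3 is a limit of the assay, not a number: the limit of > 30000 nM in this assay, at which 1 of the 3 values shown sits.

Trifluoromethyl in place of hydrogen on an aromatic carbon gives an at least 1.5-fold higher number from compound 1 to compound 3 (0.18 log units; that floor lies within the scatter), so the effect of that change stays unsettled.

The compounds shown cannot separate the ring nitrogen of quinolin-3-yl from its second ring. Naphthalen-2-yl or pyridin-3-yl on the amine nitrogen would tell these two apart.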